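The source may hold more compounds than are shown below. What is called first, only, known or untested is meant among the compounds shown, and "the series" means these compounds.

Measured so far in a functional assay on Maver1 cells (Homo sapiens) for inhibition, read by luminescence and CellTiter-Glo, with a stated time of 72 h; on this read-out higher numbers stand for weaker inhibition and lower numbers for stronger inhibition:

Compound 1 `O=C(CCl)N1CCCC(n2nc(-c3ccc(Oc4ccccc4)cc3)cc2CO)C1` gives 1100 nM.
Compound 2 `O=C(CCl)Nc1ccc(Cn2nc(-c3ccc(Oc4ccccc4)cc3)cc2CO)cc1` gives 400 nM.

Of these two numbers, compound 1 has the higher one, which on this read-out means the weaker inhibition. Compound 2 lies below it by a gap that is beyond the usual scatter of repeated measurements, so the two compounds are genuinely distinguished by this assay. The two also differ in more than one part of the structure at once, so their gap cannot be tied to any single change.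

The next compound, compound 3 `O=C(O)c1cc(-c2ccc(Oc3ccccc3)cc2)nn1C1CCCN(C(=O)CCl)C1`, has not yet been measured. It is derived from compound 1 by one change: carboxy in place of hydroxymethyl on an aromatic carbon. Within the data shown here, no measured pair of compounds shows this same change, so there is no measured step to lean on; the expectation rests only on the value of compound 1 and on the nature of the swap.

The step from compound 1 to compound 3 is expected to be a 2.7-fold higher number from compound 1 to compound 3 (0.44 log units; beyond the scatter), an upward step of modest size. Compound 3 is therefore estimated to give about 3000 nM in this assay, within a range from 800 nM to 12000 nM.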

Compound 3, half-maximal inhibitory concentration: 400 nM
Compound 3: middle estimate off by 7.5-fold (0.88 log units), on the high side; the whole stated range lies above it.
By their numbers in this assay, from the lowest: compounds 2 and 3 (each within the scatter of the next); then compound 1.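

Placing carboxy on the aromatic carbon next to the ring nitrogen, where hydroxymethyl stood, gives a 2.8-fold lower number from compound 1 to compound 3 (0.44 log units; beyond the scatter) in this assay and so stronger inhibition, which shows that this position responds to the group it carries and that carboxy is accepted there. The gap between the first two compounds could not be tied to any single change, whereas this step belongs to one substitution on an otherwise unchanged structure, with the 1-((chloromethyl)carbonyl)piperidin-3-yl group kept in place. Nothing available here explains why the swap lowers the number, so this remains an observation from a single pair.

As far as these compounds go, what stays open is whether the same swap would move the number in the same direction in compound 2, which carries hydroxymethyl at the same place on a different remaining structure. From the compounds shown here alone, it is also open whether the improvement needs the free carboxy group itself, and a methyl ester, a primary amide or an aminomethyl group on the same carbon would help to separate these possibilities.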